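Carbamoyl in place of pyridin-3-yl in compound 2

The compounds below may be only part of what the source reports. "The series", "measured", "known", "first", "only" and "open" are said of these compounds alone.

Within the data shown here, in an ADME assay on MT4 cells (Homo sapiens) for cytotoxicity, read by MTT assay, with a stated time of 5 days (on this read-out lower numbers stand for higher toxicity in this test and higher numbers for lower toxicity in this test), compound 2 `Cc1cc(C)cc(S(=O)(=O)c2c(C(=O)N[C@@H]3CCN(Cc4cccnc4)C3)[nH]c3ccc(Cl)cc23)c1` gives 36500 nM, the higher of the two numbers measured so far. Among the measured compounds shown here, the only other measured compound, compound 1 `Cc1cc(C)cc(S(=O)(=O)c2c(C(N)=O)[nH]c3ccc(Cl)cc23)c1`, carries the amide hydrogen in place of the 1-((pyridin-3-yl)methyl)pyrrolidin-3-yl group and gives 13000 nM.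

Compound 3 `Cc1cc(C)cc(S(=O)(=O)c2c(C(=O)N[C@@H]3CCN(CC(N)=O)C3)[nH]c3ccc(Cl)cc23)c1` differs from compound 2 in one place: carbamoyl in place of pyridin-3-yl on a saturated chain carbon bound to an amine nitrogen in a ring. Cut one bond further out, the change reads (pyridin-3-yl)methyl to carbamoylmethyl.

For the measured compounds named here, only one measured step bears on this, and only loosely. Going by the values given here, it adds the whole substituent at once, so no measured pair isolates the pyridin-3-yl group. A change at the end of that substituent is therefore expected to give no step beyond the scatter, in either direction, since the whole substituent brought only a 2.8-fold higher number from compound 1 to compound 2 (0.45 log units; beyond the scatter).

The estimated change in this assay is a 1.0-fold lower number from compound 2 to compound 3 (0.02 log units; within the scatter). For compound 3 the expected value is 35000 nM, with an estimated range from 14000 nM to 85000 nM.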

Compound 3, half-maximal cytotoxic concentration: 31000 nM
Beside the measured number, compound 3's estimate is 1.1-fold (0.05 log units) above it; measured number inside the range.
By their numbers in this assay, from the lowest: compound 1; then compounds 3 and 2 (each within the scatter of the next).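

Replacing pyridin-3-yl with carbamoyl on a saturated chain carbon bound to an amine nitrogen in a ring gives, in this assay, a 1.2-fold lower number from compound 2 to compound 3 (0.07 log units; within the scatter), so the two compounds cannot be told apart on this read-out even though the aromatic ring is gone and a hydrogen-bond donor has entered. The second substituent on the amide-type nitrogen also gives a 2.4-fold higher number from compound 1 to compound 3 (0.38 log units; beyond the scatter), and so both substituents shown, which share the 1-(methyl)pyrrolidin-3-yl portion and differ at its end, stand above compound 1, with no compound here going against this. Nothing measured here explains this outcome or accounts for the difference from compound 1.

On these data alone, it remains open whether an amine, a carboxylic acid or a longer chain ending in carbamoyl, placed on the same amine nitrogen in a ring, would stay within the scatter of compound 2 and compound 3. As far as these compounds go, it also remains open whether the plain pyrrolidin-3-yl group, with only hydrogen on that nitrogen, would already differ from compound 1 on this read-out.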